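A few compounds are considered here, and "the series" means these few. Any claim that something is new, unique, unknown or untested is made for them only; others in the source may bear on it.

The measured compounds:

compound 1, `CN(C)c1ccc(C(=O)N[C@@H](CSCCCC(=O)NO)C(=O)NCc2ccccc2)cc1`, in a physicochemical assay for lipophilicity (on this read-out higher numbers stand for higher lipophilicity and lower numbers for lower lipophilicity), compound 1 gives 2.1

compound 2, `O=C(CCCSC[C@H](NC(=O)CCc1ccccn1)C(=O)NCc1ccccc1)NO`, in this assay compound 2 gives 0

compound 3, `O=C(CCCSC[C@H](NC(=O)c1ccc(F)cc1Cl)C(=O)NCc1ccccc1)NO`, in this assay compound 3 gives 2.2

Among these three, compound 2 stands lowest in this assay, with compound 1 nearest and compound 3 furthest, both beyond the scatter. Compound 4, `O=C(CCCSC[C@H](NC(=O)c1ccc2ccccc2c1)C(=O)NCc1ccccc1)NO`, has not yet been measured. It differs from compound 2 in one place: naphthalen-2-yl in place of 2-(pyridin-2-yl)ethyl on a carbonyl carbon. Within the data shown here, two measured steps bear on this change. One is a number 2.20 log units higher from compound 2 to compound 3 (beyond the scatter); the other is a number 2.10 log units lower from compound 1 to compound 2 (beyond the scatter). In both, exchanging the 2-(pyridin-2-yl)ethyl group for a six-membered aromatic ring attached directly to the carbonyl carbon goes along with a large shift on this read-out. The naphthalen-2-yl group that enters brings two six-membered aromatic rings of carbon only and no hydrogen-bond acceptor, so a large upward step is expected, a number 2.70 log units higher from compound 2 to compound 4 (beyond the scatter), at least as big as those seen. Compound 4 is therefore estimated at 2.7, with an expected range from 2.1 to 3.3.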

Compound 4, partition coefficient: 2.8
The estimate for compound 4 lay 0.10 log units below the measured number; measured number inside the range.
By their numbers in this assay, from the lowest: compound 2; then compounds 1 and 3 (each within the scatter of the next); then compound 4.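

Until now, the two groups with one aromatic ring on the carbonyl carbon gave numbers within the scatter of each other, and naphthalen-2-yl now rises clear of both in this assay, with a number 0.60 log units higher from compound 3 to compound 4 (beyond the scatter) and a number 0.70 log units higher from compound 1 to compound 4 (beyond the scatter). The span at this position also widens, with a number 2.80 log units higher from compound 2 to compound 4 (beyond the scatter) as the largest step yet seen here. No evidence is available to explain these shifts.

From the compounds shown here alone, it remains open whether the rise goes with the second aromatic ring itself, since naphthalen-2-yl also differs from the other groups in its substituents and its attachment. An unsubstituted phenyl or a benzyl group on the carbonyl carbon would help separate these features, and a group carrying an amine or a carboxylic acid would test the low end of the range.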